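Turning a Carboxy Group into a Pyridinyl Amide

A few compounds are considered here, and "the series" means these few. Any claim that something is new, unique, unknown or untested is made for them only; others in the source may bear on it.

Compound 1 `COc1cccc(OC)c1C(=O)Nc1c[nH]nc1C(=O)O` was tested in an ADME assay on MRC5 cells (Homo sapiens) for inhibition, with a stated time of 72 h; a higher number here means that more compound is needed for the effect, a lower number that less compound is needed. In this test compound 1 reaches only the assay limit, > 50000 nM. Compound 2 `CO[C@H]1CC[C@H](NC(=O)c2n[nH]cc2NC(=O)C2CCOCC2)CC1` was tested the same way, and compound 2 also stops at the limit, > 50000 nM. Both readings sit at the limit of > 50000 nM in this assay, at which 2 of the 2 values shown sit, so there is no measured range within which to place compound 1; it stands at the edge of what the test can report. The step under consideration leads to compound 3 `COc1cccc(OC)c1C(=O)Nc1c[nH]nc1C(=O)Nc1ccncc1`, which carries (pyridin-4-yl)amino in place of hydroxy on a carbonyl carbon. Cut one bond further out, carboxy becomes (pyridin-4-yl)carbamoyl. Among the compounds with values here, no measured pair of this kind is at hand, so the expected step is an at least 1.2-fold lower number from compound 1 to compound 3 (0.09 log units; that floor lies within the scatter), meaning a change not clearly beyond the usual scatter, with a limit still the most likely outcome. Compound 3 is therefore estimated at 40000 nM, expected within 10000 nM to 100000 nM.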

Compound 3, half-maximal effective concentration: > 50000 nM
Compound 3 ended at the assay's limit; the forecaster's own chance of this, stated with the estimate: 60%; at least 1.2-fold (0.09 log units) between middle value and limit.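

In this assay compound 3 gives > 50000 nM, which is a limit of the assay. Compound 1 also stops at a limit, so no step can be read from compound 1 to compound 3: the limit of > 50000 nM in this assay, at which 3 of the 3 values shown sit.

The compounds shown leave open whether (pyridin-4-yl)amino in place of hydroxy changes the concentration needed in this assay at all, and in which direction.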